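A Phenyl Swap in a Flat Series

The source may report more compounds than this note shows. Statements on the series, on what has been measured and on what is new or still open speak of the compounds shown alone.

In a functional assay on DU-145 cells (Homo sapiens) for cytotoxicity, read by MTT assay (a lower number here means a stronger inhibitor, a higher number a weaker inhibitor), compound 1 (`CC(=O)OCCO[C@H](CC=C(C)C)C1=CC(=O)c2c(O)ccc(O)c2C1=O`) gives 15500 nM while compound 3 (`CCC(O)CO[C@H](CC=C(C)C)C1=CC(=O)c2c(O)ccc(O)c2C1=O`) gives 16400 nM and compound 2 (`CC[C@](C)(O)CC(=O)O[C@H](CC=C(C)C)C1=CC(=O)c2c(O)ccc(O)c2C1=O`) gives 20500 nM here. Compound 2 therefore sits within the scatter of both others, as the steps of a 1.3-fold higher number from compound 1 to compound 2 (0.12 log units; within the scatter) and a 1.3-fold lower number from compound 2 to compound 3 (0.10 log units; within the scatter) show. Compound 4 (`CC(C)=CC[C@@H](OC(=O)CC(O)c1ccccc1)C1=CC(=O)c2c(O)ccc(O)c2C1=O`) carries hydroxy(phenyl)methyl in place of 1-hydroxy-1-methylpropyl on a saturated chain carbon bound to a carbonyl carbon. Going by the values given here, no measured step adds a ring, so the evidence is indirect. Still, the third step of a 1.1-fold higher number from compound 1 to compound 3 (0.02 log units; within the scatter) also stays small, so no step beyond the scatter is expected. The expected step is a 1.4-fold lower number from compound 2 to compound 4 (0.14 log units; within the scatter) in this estimate. For compound 4 the estimated value is 15000 nM with an expected range from 7500 nM to 30000 nM overall.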

Compound 4, half-maximal inhibitory concentration: 17000 nM
For compound 4 the middle estimate is 1.1-fold (0.05 log units) below the measured one; the measured number falls inside the stated range.
By their numbers in this assay, from the lowest: compounds 1, 3, 4 and 2 (each within the scatter of the next).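

Compound 4 places an aromatic ring of carbon only on this saturated chain carbon bound to a carbonyl carbon, something the earlier side chains lack, and the swap gives a 1.2-fold lower number from compound 2 to compound 4 (0.08 log units; within the scatter) in this assay. At this position, then, the change from an open-chain group to hydroxy(phenyl)methyl stays within the scatter. Nothing measured here gives a reason for this flat result.

Still open, from the compounds shown here alone, is whether an amine or a carboxylic acid at this position would give a step beyond the scatter. The same question holds for a fluorine on the new phenyl ring.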